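The compounds below may be only part of what the source reports. "The series", "measured", "known", "first", "only" and "open" are said of these compounds alone.

Measured in an in vitro ADME assay on microsomes from liver (Homo sapiens) for metabolic stability, with a stated time of 15 min; a higher number here means faster removal of the compound, a lower number slower removal:
compound 1 `COCc1cc(OC)c(-c2cccc3c(N(CC4CCOCC4)CC4CC4)c(SC)nn23)c(OC)c1` gives 340 mL.min-1.g-1
compound 2 `CCc1nn2c(-c3c(COC)cc(OC)cc3OC)cccc2c1N(CC1CCOCC1)CC1CC1` gives 530 mL.min-1.g-1
compound 3 `CCc1nn2c(-c3c(C)cc(C)cc3OC)cccc2c1N(CC1CC1)CC1CCOC1` gives 1350 mL.min-1.g-1

Compound 3 stands highest of the three numbers in this assay; compound 2 is nearest, with a lower number beyond the scatter, and compound 1 is furthest, lower still and also beyond the scatter. Going by the values given here, no step between measured compounds that differ in one place is available. Compound 4 `CCc1nn2c(-c3c(C)cc(C)cc3OC)cccc2c1N(CCCF)CC1CC1` differs from compound 3 as 2-fluoroethyl in place of oxolan-3-yl on a saturated chain carbon bound to a nitrogen on an aromatic ring; cut one bond further out, the change reads (oxolan-3-yl)methyl to 3-fluoropropyl. Among the compounds with values here, nothing among the measured compounds isolates this change, so no step beyond the scatter is expected in either direction in this assay. Compound 4 is expected to give 1100 mL.min-1.g-1 (range 500 mL.min-1.g-1 to 2500 mL.min-1.g-1). The expected step is a 1.2-fold lower number from compound 3 to compound 4 (0.09 log units; within the scatter).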

Compound 4, intrinsic clearance in microsomes: 1410 mL.min-1.g-1
Beside the measured number, compound 4's estimate is 1.3-fold (0.11 log units) below it; low and high end bracket the measured number.
By their numbers in this assay, from the lowest: compounds 1 and 2 (each within the scatter of the next); then compounds 3 and 4 (each within the scatter of the next).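

In this assay, going by these compounds alone, 2-fluoroethyl in place of oxolan-3-yl on a saturated chain carbon bound to a nitrogen on an aromatic ring gives a 1.0-fold higher number from compound 3 to compound 4 (0.02 log units; within the scatter), the first step that isolates one place. At this place, the five-membered ring and its hydrogen-bond acceptor can thus give way to an open fluorinated chain with the two numbers staying within the scatter of each other. Nothing available explains this result.

From the compounds shown here alone, whether an amine or a carboxylic acid at this place would leave the number within the scatter stays open. Going by these compounds, a longer chain is equally open.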